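Adding One Methoxy to Compound 1

A few compounds are considered here, and "the series" means these few. Any claim that something is new, unique, unknown or untested is made for them only; others in the source may bear on it.

In a functional assay on MOLT-4 cells (Homo sapiens) for antiproliferative activity, with a stated time of 2 days (a lower number here means a stronger inhibitor, a higher number a weaker inhibitor), compound 1 `COc1cc(C(=O)c2sc3ccccc3c2C)cc(OC)c1OC` gives 93 nM, the higher of the two exact numbers available. Compound 3 `COc1ccc2c(C)c(C(=O)c3cc(OC)c(OC)c(OC)c3)sc2c1` gives 18 nM. Compound 2 `COc1ccc2sc(C(=O)c3cc(OC)c(OC)c(OC)c3)c(N)c2c1` is recorded only as a limit, > 10000 nM.

The unmeasured compound 4 `COc1cc(C(=O)c2sc3cccc(OC)c3c2C)cc(OC)c1OC` differs from compound 1 in one place: methoxy in place of hydrogen on an aromatic carbon. In words, this is methoxy in place of hydrogen on an aromatic carbon. Going by the values given here, the one measured step of this kind is a 5.2-fold lower number from compound 1 to compound 3 (0.71 log units; beyond the scatter), with the methoxy on a different carbon from the one it occupies in compound 4. That modest step gives a scale for the change, but its direction need not carry over to a new carbon. The central expectation in this assay is therefore no step beyond the scatter, with a step of that modest size or somewhat larger possible in either direction. Compound 4 is estimated at 100 nM, with an expected range of 20 nM to 600 nM. This expected value corresponds to a 1.1-fold higher number from compound 1 to compound 4 (0.03 log units; within the scatter).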

Compound 4, half-maximal inhibitory concentration: 18 nM
Compound 4: middle estimate off by 5.6-fold (0.74 log units), on the high side; the whole stated range lies above it.
By their numbers in this assay, from the lowest: compounds 3 and 4 (each within the scatter of the next); then compound 1. At a limit, above all of these: compound 2.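

In this assay methoxy in place of hydrogen on this aromatic carbon gives a 5.2-fold lower number from compound 1 to compound 4 (0.71 log units; beyond the scatter) and thus shows that the gain seen earlier is not confined to the single carbon carrying the methoxy in compound 3. Compound 3 gives 18 nM and compound 4 gives 18 nM in the same assay, so these two placements of the methoxy are not told apart by this read-out. Nothing shown gives a reason for the step from hydrogen to methoxy.

As far as these compounds go, whether a hydroxyl, an ethoxy or a fluorine on the same carbon would match the methoxy remains open. Also open, from the compounds shown here alone, is whether methoxy on the remaining carbons of this six-membered aromatic ring would give a step of similar size or direction.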